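Ester-to-acid change at the biphenyl in a bombesin series

This account rests on a few compounds, and the source may have more. Where it says the series, first, only, none or still open, it means among the compounds named here.

Working notes on the shared core. Compound 1 `COC(=O)c1ccccc1-c1ccc(CCc2ncc(CC(C)(C)C)n2CC(=O)O)cc1` gives 968 nM in an assay on cells for agonist activity at Bombesin receptor subtype-3 (Homo sapiens), read by HTRF and inositol phosphate accumulation, with a stated time of 1 h (on this read-out lower numbers stand for an effect already at smaller amounts and higher numbers for an effect only at larger amounts of compound), and stands highest of the three numbers measured; compound 3 `COC(=O)c1c(F)cccc1-c1ccc(CCc2ncc(CC(C)(C)C)n2CCO)cc1` gives 21 nM and compound 2 `COC(=O)c1c(F)cccc1-c1ccc(CCc2ncc(CC(C)(C)C)n2CCC(=O)O)cc1` gives 1 nM, both far below compound 1. Within the data shown here, the one single-point step measured, a 21-fold higher number from compound 2 to compound 3 (1.32 log units; beyond the scatter), concerns the acid chain on the aromatic nitrogen and not the biphenyl ester. Among the measured compounds shown here, compound 4 `CC(C)(C)Cc1cnc(CCc2ccc(-c3ccccc3C(=O)O)cc2)n1CC(=O)O` differs from compound 1 by hydrogen in place of methyl on an oxygen next to a carbonyl group; no measured pair speaks to this change, so no direction can be drawn from the series. Compound 4 is therefore expected near compound 1, with an estimated step of a 1.2-fold higher number from compound 1 to compound 4 (0.09 log units; within the scatter), at about 1200 nM and a wide range from 250 nM to 6000 nM.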

Compound 4, half-maximal effective concentration: 897 nM
The estimate for compound 4 lay 1.3-fold (0.13 log units) above the measured number; measured number inside the range.
By their numbers in this assay, from the lowest: compound 2; then compound 3; then compounds 4 and 1 (each within the scatter of the next).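

In this assay, among these compounds, the change from methoxycarbonyl to carboxy gives a 1.1-fold lower number from compound 1 to compound 4 (0.03 log units; within the scatter), the first reading at this position. On the core of compound 1, the two groups therefore cannot be told apart. No measurement bears on why they read alike.

On these data alone, what a primary amide or a tetrazole would give in place of the carboxy stays open. So does whether the same change reads alike on the core of compound 2, which gives 1 nM as the methyl ester.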